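The source may hold more compounds than are shown below. What is called first, only, known or untested is meant among the compounds shown, and "the series" means these compounds.

Within the data shown here, in a functional assay on HeLa cells (Homo sapiens) for antiproliferative activity, read by MTT assay, with a stated time of 24 h (a lower number here means a stronger inhibitor, a higher number a weaker inhibitor), compound 1 `O=[N+]([O-])c1ccc(CSc2nnc(-c3ccc4c(c3)OCCO4)n2-c2ccccc2)cc1` gives 36200 nM and compound 2 `Clc1cccc(CSc2nnc(-c3ccc4c(c3)OCCO4)n2-c2ccccc2)c1` gives 15000 nM as the lowest of the two numbers so far. Compound 3 `COc1cccc(CSc2nnc(-c3ccc4c(c3)OCCO4)n2-c2ccccc2)c1` carries methoxy in place of chloro on an aromatic carbon, meta to a large group (methoxy in place of chloro on an aromatic carbon). Among the measured compounds shown here, the only measured step (a 2.4-fold lower number from compound 1 to compound 2 (0.38 log units; beyond the scatter)) is modest and involves other groups, 3-chlorophenyl in place of 4-nitrophenyl, so it bears only loosely on this change. A small step to a higher number is expected, close to the scatter. For compound 3 the estimated value is 20000 nM within a range of 9000 nM to 45000 nM on present data. The expected step is a 1.3-fold higher number from compound 2 to compound 3 (0.12 log units; within the scatter) at this stage.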

Compound 3, half-maximal inhibitory concentration: > 100000 nM
Compound 3 ended at the assay's limit; the forecaster's own chance of this, stated with the estimate: 5%; middle value at least 5.0-fold (0.69 log units) away from the limit.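

In this assay compound 3 gives > 100000 nM, a limit of the assay and not a number: the limit of > 100000 nM in this assay, at which 1 of the 3 values shown sits.

Methoxy in place of chloro gives an at least 6.6-fold higher number from compound 2 to compound 3 (0.82 log units; beyond the scatter), so the group on this aromatic carbon alone moves the number beyond the scatter, which the earlier step, with both group and place changed, could not show. 3-Methoxyphenyl in place of 4-nitrophenyl gives an at least 2.7-fold higher number from compound 1 to compound 3 (0.44 log units; beyond the scatter), leaving methoxy on the weak side of both earlier groups.

Open, as far as these compounds go, is whether a fluoro, a methyl or a hydroxy on this carbon stays close to chloro or follows methoxy. From the compounds shown here alone, the full size of both steps also stays unknown.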